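Widening the Amine Substituent of Compound 1

The compounds below may be only part of what the source reports. "The series", "measured", "known", "first", "only" and "open" are said of these compounds alone.

Compound 1 `CCNCCCOc1ccc2cc(NC(=O)c3ccc(O)c(CC=C(C)C)c3)c(=O)oc2c1C` gives 980 nM in a functional assay on MCF7 cells (Homo sapiens) for antiproliferative activity (on this read-out higher numbers stand for weaker inhibition and lower numbers for stronger inhibition), the lowest of the two numbers, and compound 2 `CC(C)=CCc1cc(C(=O)Nc2cc3ccc(OCCCNCCO)c(C)c3oc2=O)ccc1O` gives 1560 nM. Compound 3 `CC(C)=CCc1cc(C(=O)Nc2cc3ccc(OCCCNC(C)(C)c4ccccc4)c(C)c3oc2=O)ccc1O` differs from compound 1 by 1-methyl-1-phenylethyl in place of ethyl on an amine nitrogen. For the measured compounds named here, the only measured step, a 1.6-fold higher number from compound 1 to compound 2 (0.20 log units; within the scatter), alters a different position and is within the scatter, so nothing in these data connects a change at the amine nitrogen with a shift in either direction. Compound 3 is therefore expected to show a 1.1-fold lower number from compound 1 to compound 3 (0.04 log units; within the scatter), a step not beyond the scatter. The estimated value for compound 3 is 900 nM, with a range from 250 nM to 3000 nM.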

Compound 3, half-maximal inhibitory concentration: 1070 nM
Estimate against measurement, compound 3: 1.2-fold (0.08 log units) below; low and high end bracket the measured number.
By their numbers in this assay, from the lowest: compounds 1, 3 and 2 (each within the scatter of the next).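

Placing 1-methyl-1-phenylethyl on the amine nitrogen in place of ethyl gives a 1.1-fold higher number from compound 1 to compound 3 (0.04 log units; within the scatter), and placing it there in place of 2-hydroxyethyl gives a 1.5-fold lower number from compound 2 to compound 3 (0.16 log units; within the scatter). In this assay, a substituent with a six-membered aromatic ring on this nitrogen therefore stays within the scatter of both the ethyl and the 2-hydroxyethyl substituents. No other measurement bears on this result. The compounds shown leave open whether a tertiary amine carrying two methyl groups, or an amide in place of the amine, would move the number beyond the scatter.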